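The compounds below may be only part of what the source reports. "The series", "measured", "known", "first", "only" and "open" are said of these compounds alone.

Measured in a functional assay on K562 cells (Homo sapiens) for inhibition, read by trypan blue exclusion, with a stated time of 72 h; on this read-out lower numbers stand for stronger inhibition and higher numbers for weaker inhibition:

Compound 1 `CCn1c(=O)c(S(=O)(=O)c2ccc(F)cc2F)cc2cnc(Nc3ccc4[nH]ccc4c3)nc21`: 750 nM
Compound 2 `O=c1c(S(=O)(=O)c2ccc(F)cc2F)cc2cnc(Nc3ccc4[nH]ccc4c3)nc2n1CC1CC1`: 1000 nM

These two compounds share one core and differ only in the group on an aromatic nitrogen. Within the data shown here, on the numbers, compound 2 stands level with compound 1, its only measured neighbour. Among the measured compounds shown here, the one measured step, a 1.3-fold higher number from compound 1 to compound 2 (0.12 log units; within the scatter), places cyclopropyl in place of methyl on a saturated chain carbon bound to an aromatic nitrogen.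

The unmeasured compound 3 `O=c1c(S(=O)(=O)c2ccc(F)cc2F)cc2cnc(Nc3ccc4[nH]ccc4c3)nc2n1C1CCCCC1` changes the group on that nitrogen again: cyclohexyl in place of cyclopropylmethyl on an aromatic nitrogen. In short, this is cyclohexyl in place of cyclopropylmethyl on an aromatic nitrogen. For the measured compounds named here, no measured compound carries cyclohexyl, so the single step above is only a loose guide. Going by the values given here, still, it is the only evidence for changes at this nitrogen, and it stayed within the scatter. With only a 1.3-fold higher number from compound 1 to compound 2 (0.12 log units; within the scatter) to go on, no step beyond the scatter is expected in this assay, and the data argue for no firm direction. The estimated step is a 1.3-fold lower number from compound 2 to compound 3 (0.10 log units; within the scatter). For compound 3 the estimated value is 800 nM, with an expected range of 250 nM to 2500 nM.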

Compound 3, half-maximal inhibitory concentration: 10000 nM
Estimate against measurement, compound 3: 13-fold (1.10 log units) below, and the stated range ends below it.
By their numbers in this assay, from the lowest: compounds 1 and 2 (each within the scatter of the next); then compound 3.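

This position on the aromatic nitrogen is not indifferent to the group it carries: in this assay, ethyl and cyclopropylmethyl gave values within the scatter of each other, yet cyclohexyl weakens inhibition, with a 10-fold higher number from compound 2 to compound 3 (1.00 log units; beyond the scatter) and a 13-fold higher number from compound 1 to compound 3 (1.12 log units; beyond the scatter) as the two steps. The tolerance suggested by the first two compounds therefore does not extend to every carbon-only group at this nitrogen. Cyclopropylmethyl has 4 heavy atoms and a three-membered ring, whereas cyclohexyl has 6 heavy atoms and a six-membered ring; both have no hydrogen-bond donors or acceptors and no net charge, and nothing measured here accounts for the difference in activity.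

The compounds shown leave open whether the weaker inhibition follows the number of carbons, the size of the ring, or the attachment of a ring carbon directly to the nitrogen. Isopropyl, cyclopentyl and a straight hexyl chain at this nitrogen would each bear on that question, as would an amine on the cyclohexyl ring.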